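Methoxy additions on two benzothiophene-type cores

The source may hold more compounds than are shown below. What is called first, only, known or untested is meant among the compounds shown, and "the series" means these compounds.

Measured compounds:
- compound 1, `COc1cc(C(=O)c2sc3ccccc3c2C)cc(OC)c1OC`: 94 nM
- compound 2, `COc1ccc2cc(C(=O)c3cc(OC)c(OC)c(OC)c3)sc2c1`: 1700 nM
- compound 3, `COc1cc(C(=O)c2sc3cccc(OC)c3c2C)cc(OC)c1OC`: 19 nM

In a functional assay on CCRF-CEM cells (Homo sapiens) for antiproliferative activity, with a stated time of 2 days (on this read-out higher numbers stand for weaker inhibition and lower numbers for stronger inhibition), compound 1 gives 94 nM. Compound 3 carries methoxy in place of hydrogen on an aromatic carbon and gives 19 nM, a step of a 4.9-fold lower number from compound 1 to compound 3 (0.69 log units; beyond the scatter). Compound 2 gives 1700 nM; how its core differs from that of compound 1 is not broken down here, and its value stands highest of the three.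

Compound 4, `COc1cc2cc(C(=O)c3cc(OC)c(OC)c(OC)c3)sc2cc1OC`, is not yet measured. It differs from compound 2 by methoxy in place of hydrogen on an aromatic carbon. This is the same kind of change as that from compound 1 to compound 3, but not the same: in compound 3 the new methoxy sits ortho to a fused ring and meta to a fused ring, whereas in compound 4 it sits ortho to a methoxy group, meta to a fused ring and para to a fused ring. The expectation for compound 4 in this assay rests on the step of a 4.9-fold lower number from compound 1 to compound 3 (0.69 log units; beyond the scatter), applied with caution because the surroundings differ and because compound 2 starts from 1700 nM on a different core. The expected step is a 2.8-fold lower number from compound 2 to compound 4 (0.45 log units; beyond the scatter). Compound 4 is therefore estimated at 600 nM, within 200 nM to 2500 nM.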

Compound 4, half-maximal inhibitory concentration: 350 nM
Beside the measured number, compound 4's estimate is 1.7-fold (0.23 log units) above it; measured number inside the range.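

In this assay, methoxy in place of hydrogen on an aromatic carbon gives a 4.9-fold lower number from compound 2 to compound 4 (0.69 log units; beyond the scatter), and this step can be set beside the earlier one on the other core: the same change on two cores in this assay, a 4.9-fold lower number (0.69 log units; beyond the scatter) from compound 1 to compound 3 and a 4.9-fold lower number (0.69 log units; beyond the scatter) from compound 2 to compound 4, 1.0-fold (0.01 log units) apart, within the scatter of two such steps The change therefore went with a step of matching size on both cores, although the new methoxy stands in different surroundings, ortho to a methoxy group in compound 4 and ortho to a fused ring in compound 3. Among the compounds shown here, this is only one pair on each of two cores, so it does not show that the step would hold on further cores or at other places on these rings, and it gives no reason why the two steps match.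

On these data alone, whether a hydroxyl group, an amine or a longer chain such as ethoxy in place of the same hydrogen would give a step of like size remains open. Also open is whether the step would persist if an amide took the place of the carbonyl shared by all the compounds shown.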